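Moving a Nitro Group onto the Dichlorophenyl End

This account rests on a few compounds, and the source may have more. Where it says the series, first, only, none or still open, it means among the compounds named here.

Measured so far:
compound 1, `O=C(/C=C/c1ccc(Oc2ncnc3ccc(Cl)cc23)cc1)/C=C/c1c(Cl)cccc1Cl`, 9300 nM
compound 2, `O=C(/C=C/c1ccc(Oc2ncnc3ccc(Cl)cc23)cc1)/C=C/c1ccc(Cl)c(Cl)c1`, 18800 nM
compound 3, `O=C(/C=C/c1ccc(Oc2ncnc3ccc(Cl)cc23)cc1)/C=C/c1cccc(Cl)c1Cl`, 10200 nM

The three compounds share one core and differ only in the substitution of the phenyl ring on a double-bonded chain carbon bound to a double-bonded chain carbon. In a functional assay on PC-3 cells (Homo sapiens) for inhibition, read by MTT assay, with a stated time of 72 h (a higher number here means a weaker inhibitor, a lower number a stronger inhibitor), compound 1 gives 9300 nM, compound 2 gives 18800 nM and compound 3 gives 10200 nM. Compound 3 stands second highest of the three numbers: its nearest neighbour is compound 1, at a 1.1-fold higher number from compound 1 to compound 3 (0.04 log units; within the scatter), and the furthest is compound 2, at a 1.8-fold lower number from compound 2 to compound 3 (0.27 log units; within the scatter), both within the scatter. Going by the values given here, the only step that reaches beyond the scatter is a 2.0-fold higher number from compound 1 to compound 2 (0.31 log units; beyond the scatter), and it is modest.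

Compound 4, `O=C(/C=C/c1ccc(Oc2ncnc3ccc(Cl)cc23)cc1)/C=C/c1cc([N+](=O)[O-])ccc1Cl`, is not yet measured. It differs from compound 3 as follows: 2-chloro-5-nitrophenyl in place of 2,3-dichlorophenyl on a double-bonded chain carbon bound to a double-bonded chain carbon. Among the compounds with values here, none of the measured steps involves a nitro group; all three merely move chlorines around the same ring, and only one of them reached beyond the scatter. Within the data shown here, with no direct precedent, the expectation for a 1.1-fold higher number from compound 3 to compound 4 (0.03 log units; within the scatter) is a step no larger than the scatter, in either direction. Compound 4 is therefore estimated at 11000 nM, with a range from 5000 nM to 25000 nM.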

Compound 4, half-maximal inhibitory concentration: 3150 nM
Beside the measured number, compound 4's estimate is 3.5-fold (0.54 log units) above it, and the stated range ends above it.
By their numbers in this assay, from the lowest: compound 4; then compounds 1, 3 and 2 (each within the scatter of the next, the first and the last beyond it).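

Within this assay the place on a double-bonded chain carbon bound to a double-bonded chain carbon proves more responsive than the chlorine shifts alone suggested: bringing in 2-chloro-5-nitrophenyl gives a 3.2-fold lower number from compound 3 to compound 4 (0.51 log units; beyond the scatter) and a 3.0-fold lower number from compound 1 to compound 4 (0.47 log units; beyond the scatter) and a 6.0-fold lower number from compound 2 to compound 4 (0.78 log units; beyond the scatter) as its three steps, all beyond the scatter, whereas only one step among the dichlorophenyl compounds reached that far. Compound 4 is thus the strongest inhibitor of the four, and the ring at this place is shown to accept a group other than chlorine with a gain rather than a loss. Nothing shown here explains that gain.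

The change takes away one chlorine and brings in the nitro group in a single step, so these compounds cannot tell how much of the step belongs to each, and a ring carrying the nitro group with two chlorines, or a single chlorine alone, would be needed to separate them. As far as these compounds go, whether an amine or a nitrile in the nitro group's place would give a similar step also stays open.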